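From Methyl to Pyridin-2-yl on a Ring Amine Nitrogen

This account rests on a few compounds, and the source may have more. Where it says the series, first, only, none or still open, it means among the compounds named here.

Of the compounds shown here, two built on a shared core have been tested in a functional assay on CCRF-CEM cells for antagonist activity at C-X-C chemokine receptor type 4 (Homo sapiens), read by calcium flux, with stated times of 25 min and 90 s; on this read-out lower numbers stand for stronger inhibition and higher numbers for weaker inhibition. Compound 1 `CC(C)N1CCN(c2cccc3c2C[C@H](CN(C)[C@H]2CCCc4cccnc42)NC3)CC1` carries an isopropyl group on an amine nitrogen in a ring and in this assay gives 16.9 nM. Compound 2 `CN1CCN(c2cccc3c2C[C@H](CN(C)[C@H]2CCCc4cccnc42)NC3)CC1` carries a methyl group at that same position and in this assay gives 29.6 nM. Going by the values given here, the one step between them, a 1.8-fold higher number from compound 1 to compound 2 (0.24 log units; within the scatter), shows that exchanging these two small alkyl groups does not move the read-out beyond what repeated measurements would show. Compound 2 thus stands at a number that, of the two recorded, cannot be told apart from that of compound 1.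

Compound 3 `CN(C[C@H]1Cc2c(cccc2N2CCN(c3ccccn3)CC2)CN1)[C@H]1CCCc2cccnc21` has not yet been measured. It differs from compound 2 in one place: pyridin-2-yl in place of methyl on an amine nitrogen in a ring. Among the compounds with values here, no measured step involves an aromatic ring at this position, so the only guide is that the single recorded change there stayed within the scatter. The expectation is therefore held loosely. Compound 3 is estimated at 30 nM, with a range from 8 nM to 120 nM. This estimate means a step of a 1.0-fold higher number from compound 2 to compound 3 (0.01 log units; within the scatter) that is expected to be small.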

Compound 3, half-maximal inhibitory concentration: 17.9 nM
For compound 3 the middle estimate is 1.7-fold (0.22 log units) above the measured one, and the stated range covers the measured number.
By their numbers in this assay, from the lowest: compounds 1, 3 and 2 (each within the scatter of the next).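

Until now, this position on the amine nitrogen of the six-membered ring had been seen carrying only small alkyl groups, so the tolerated range of groups there was unknown. In this assay, a much larger group, a six-membered aromatic ring with a ring nitrogen, leaves the number within the scatter of both alkyl compounds (a 1.7-fold lower number from compound 2 to compound 3 (0.22 log units; within the scatter); a 1.1-fold higher number from compound 1 to compound 3 (0.02 log units; within the scatter)). Across the three compounds, then, methyl, isopropyl and pyridin-2-yl cannot be told apart at this position in this read-out, and there is no measured information on why this is so.

These compounds cannot show whether the nitrogen of the pyridin-2-yl ring plays any part, since the same read-out on a phenyl group, which has the ring without that nitrogen, would be needed to separate the ring from its hetero atom. As far as these compounds go, it also remains open whether this position would accept a bare hydrogen, an acetyl group or a longer chain ending in a carboxylic acid with equally little movement in the number.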